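The compounds below may be only part of what the source reports. "The series", "measured", "known", "first", "only" and "open" are said of these compounds alone.

Among the compounds with values here, compound 1, `Cc1cccc(CNc2nc3c(N)ncnc3n2[C@@H]2O[C@H](CO)[C@@H](O)[C@H]2O)c1`, is the only compound of this set that gives a number in an assay on COS-7 cells for inhibition of sodium/nucleoside cotransporter 2 (Homo sapiens), read by scintillation counting, in the presence of a further agent that is not named here; a higher number here means a weaker inhibitor, a lower number a stronger inhibitor: compound 1 gives 19000 nM. Compound 2, `CC(=O)OC[C@H]1O[C@@H](n2cnc3c(N)ncnc32)[C@H](O)[C@@H]1O`, reaches only a limit of the assay rather than a number; in this assay compound 2 gives > 100000 nM. That is the limit of > 100000 nM in this assay, at which 1 of the 2 values shown sits, so compound 1 stands alone as the one measured point, with no second number to set it against.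

The step taken from compound 1 leads to compound 3, `COc1cccc(CNc2nc3c(N)ncnc3n2[C@@H]2O[C@H](CO)[C@@H](O)[C@H]2O)c1`. The change is methoxy in place of methyl on an aromatic carbon, in words methoxy in place of methyl on an aromatic carbon. Within the data shown here, no measured pair of this kind is available for comparison, so the size of this step has to be guessed from the change itself. Its step of a 1.1-fold lower number from compound 1 to compound 3 (0.05 log units; within the scatter) is expected to be small, within or close to the usual scatter, in no clear direction. Compound 3 is therefore estimated to give about 17000 nM in this assay, with a range from 6000 nM to 50000 nM.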

Compound 3, half-maximal inhibitory concentration: 13000 nM
Compound 3: middle estimate off by 1.3-fold (0.12 log units), on the high side; the range from low to high includes it.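

In this assay, within the data shown here, the exchange of the 3-methylphenyl for the 3-methoxyphenyl group gives a 1.5-fold lower number from compound 1 to compound 3 (0.16 log units; within the scatter) and so provides the first pair of numbers in this set that can be read against each other. At this place, on an aromatic carbon of the six-membered aromatic ring and meta to a large group, the entering methoxy brings one more heavy atom and a hydrogen-bond acceptor, yet the two compounds cannot be told apart in this assay. What the pair shows is therefore limited to this one exchange: methyl and methoxy at this place read as equivalent, and nothing given here bears on why the step is this small.

The compounds shown leave open whether a group of a different kind at this same place, such as an amine, a carboxylic acid or a longer alkoxy chain, would move the number beyond the scatter in either direction. They also leave open whether methoxy or methyl would read the same at another carbon of that aromatic ring, since both compounds carry their group at the one place.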